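Changing the Aryl Group on a Ring Nitrogen

The compounds below may be only part of what the source reports. "The series", "measured", "known", "first", "only" and "open" are said of these compounds alone.

Three compounds share one core and differ only in the aryl group on an amine nitrogen in a ring. In an ADME assay on HEK293 cells for displacement of a labelled ligand from 5-hydroxytryptamine receptor 7 (Homo sapiens), read by radioligand binding, with a stated time of 1 h (on this read-out higher numbers stand for weaker inhibition and lower numbers for stronger inhibition), compound 1 `O=C1c2ccccc2S(=O)(=O)N1CCCCCCN1CCN(c2ccccc2Cl)CC1` gives 120 nM, compound 2 `O=C1c2ccccc2S(=O)(=O)N1CCCCCCN1CCN(c2ccc(Cl)c(Cl)c2)CC1` gives 258 nM, and compound 3 `COc1cccc(N2CCN(CCCCCCN3C(=O)c4ccccc4S3(=O)=O)CC2)c1` gives 305 nM. Compound 3 therefore shows the highest number of the three, although its gap to compound 2 lies within the scatter, whereas a 2.5-fold higher number from compound 1 to compound 3 (0.41 log units; beyond the scatter). Compound 4 `O=C1c2ccccc2S(=O)(=O)N1CCCCCCN1CCN(c2ccccc2C(F)(F)F)CC1` carries the change (2-(trifluoromethyl)phenyl in place of 3-methoxyphenyl on an amine nitrogen in a ring). For the measured compounds named here, no measured step involves a trifluoromethyl group; the steps that bear on it are a 2.2-fold higher number from compound 1 to compound 2 (0.33 log units; beyond the scatter) and a 2.5-fold higher number from compound 1 to compound 3 (0.41 log units; beyond the scatter), both modest and both favouring 2-chlorophenyl. A return toward that level is expected, so compound 4 is estimated at a 1.7-fold lower number from compound 3 to compound 4 (0.23 log units; within the scatter) in this assay. Compound 4 is thus expected to give 180 nM, within 60 nM to 550 nM.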

Compound 4, inhibition constant: 195 nM
Compound 4: middle estimate off by 1.1-fold (0.03 log units), on the low side; measured number inside the range.
By their numbers in this assay, from the lowest: compounds 1, 4, 2 and 3 (each within the scatter of the next, the first and the last beyond it).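

The steps to compound 4 are a 1.6-fold lower number from compound 3 to compound 4 (0.19 log units; within the scatter) and a 1.3-fold lower number from compound 2 to compound 4 (0.12 log units; within the scatter) and a 1.6-fold higher number from compound 1 to compound 4 (0.21 log units; within the scatter) and all three lie within the scatter. Compound 4 thus links the two ends of the series: unlike 3-methoxyphenyl, 2-(trifluoromethyl)phenyl stays within the scatter of 2-chlorophenyl, yet it also stays within the scatter of 3-methoxyphenyl. Nothing available accounts for these numbers. As far as these compounds go, it remains open how an unsubstituted phenyl, a 2-methoxyphenyl or a 2-cyanophenyl group would read on this ring nitrogen. From the compounds shown here alone, whether a shorter chain on the shared core would move these numbers is also open.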